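Replacing Pyrrolidinyl with Methoxycarbonyl on a Shared Core

The source may hold more compounds than are shown below. What is called first, only, known or untested is meant among the compounds shown, and "the series" means these compounds.

Compound 1 `Cc1nc2nc(C)c(CN)c(-c3ccc(Cl)cc3Cl)n2n1` and compound 2 `Cc1nc2nc(N3CCCC3)nn2c(-c2ccc(Cl)cc2Cl)c1CN` share one core and differ only in a single group on an aromatic carbon. In an assay on isolated protein for inhibition of Dipeptidyl peptidase 9 (Homo sapiens) (a lower number here means a stronger inhibitor, a higher number a weaker inhibitor), compound 1 gives > 30000 nM, which is a limit of the assay rather than a number. In this assay compound 2 likewise gives > 30000 nM, again a limit. The step that the two limits leave unreadable from compound 1 to compound 2 is therefore unreadable, since both ends rest at the limit of > 30000 nM in this assay, at which 2 of the 2 values shown sit. Going by the values given here, compound 2 thus stands at the limit, and the only other value shown is the same limit for compound 1, so no ordering between the two can be drawn.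

Compound 3 `COC(=O)c1nc2nc(C)c(CN)c(-c3ccc(Cl)cc3Cl)n2n1` is not yet measured. It differs from compound 2 by methoxycarbonyl in place of pyrrolidin-1-yl on an aromatic carbon. Among the compounds with values here, the only measured step that touches this position is a step that the two limits leave unreadable from compound 1 to compound 2, and it gives no readable size. With both measured compounds at the limit, compound 3 is expected to remain at or beyond that limit in this assay. The step that the limit leaves unreadable from compound 2 to compound 3 is expected to be none beyond the scatter. Compound 3 is therefore estimated at 50000 nM, within 15000 nM to 200000 nM.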

Compound 3, inhibition constant: > 30000 nM
Compound 3 was reported as a limit (the forecaster's own chance of this, stated with the estimate: 85%); the middle value is on the limit's open side.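

In this assay compound 3 gives > 30000 nM, which is a limit of the assay and not a number. The steps from compound 2 to compound 3 and from compound 1 to compound 3 therefore cannot be read: the limit of > 30000 nM in this assay, at which 3 of the 3 values shown sit. The compounds shown leave open how the group on the aromatic carbon affects inhibition, since none of the three has a readable number.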